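The compounds below may be only part of what the source reports. "The series", "measured", "known", "first", "only" and "open" are said of these compounds alone.

In a functional assay on MDA-MB-231 cells (Homo sapiens) for inhibition, read by sulforhodamine B assay, with a stated time of 72 h (on this read-out higher numbers stand for weaker inhibition of growth and lower numbers for stronger inhibition of growth), compound 1 `CNC(=O)/C=C/c1ccncc1-c1ccc2cc[nH]c2c1` gives 7680 nM. Compound 3 `O=C(O)/C=C/c1ccncc1-c1ccc2cc[nH]c2c1` carries the same core but a carboxy in place of the methylcarbamoyl; in this assay compound 3 reaches only the limit > 10000 nM, which is a boundary of the measurement and not a number. The change from compound 3 to compound 1 is methylamino in place of hydroxy on a carbonyl carbon, and it brought an at least 1.3-fold lower number from compound 3 to compound 1 (0.11 log units; that floor lies within the scatter); that value rests on (the limit of > 10000 nM in this assay, at which 2 of the 3 values shown sit), so the size of the step is known only as a floor.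

Compound 2 `Cn1ncc2cc(-c3cnccc3/C=C/C(=O)O)ccc21` holds the carboxy on a different core. In this assay compound 2 likewise stops at the limit > 10000 nM, again a boundary rather than a number. The difference between the core of compound 2 and the core of compound 3 is not broken down here.

Compound 4 `CNC(=O)/C=C/c1ccncc1-c1ccc2c(cnn2C)c1` is the unmeasured partner of compound 2: the change from compound 2 to compound 4 is methylamino in place of hydroxy on a carbonyl carbon, the same change that led from compound 3 to compound 1, at the same place. Because compound 1 gave 7680 nM after that change, compound 4 is expected to land in a similar region, with an expected step of an at least 1.1-fold lower number from compound 2 to compound 4 (0.04 log units; that floor lies within the scatter) in this assay. The estimate for compound 4 is 9000 nM, expected to fall between 4000 nM and 20000 nM, with a fair chance that only a limit is returned.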

Compound 4, concentration for 50% growth inhibition: > 10000 nM
Compound 4: no number, only a limit; the forecaster's own chance of this, stated with the estimate: 50%; middle value at least 1.1-fold (0.04 log units) from the limit.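

In this assay, compound 4 gives only a limit, as compound 2 does, so no step between the two can be read: the limit of > 10000 nM in this assay, at which 3 of the 4 values shown sit.

The compounds shown leave open whether methylcarbamoyl in place of carboxy changes growth inhibition at all on the core of compound 2, and how large any such change would be.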